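Acid dissociation across aryl substituent variants of the core

The source may report more compounds than this note shows. Statements on the series, on what has been measured and on what is new or still open speak of the compounds shown alone.

Measured so far, all in a physicochemical assay for acid dissociation:
Compound 1 `COc1ccc(Oc2ccc3c(NCCCNCc4cc(F)ccc4OC)ccnc3c2)cc1` gives 9.28.
Compound 2 `COc1ccc(F)cc1CNCCCNc1ccnc2cc(CCc3ccccc3)ccc12` gives 9.47.
Compound 3 `COc1ccc(-c2ccc3c(NCCCNCc4ccco4)ccnc3c2)cc1` gives 9.47.

Compound 2 stands level with compound 3 at the digits printed, the two together the highest of the three numbers, with compound 1 the furthest, and all three within the scatter of one another. Among the measured compounds shown here, the only single-point step measured, a number 0.19 log units higher from compound 1 to compound 2 (within the scatter), exchanges one group on an aromatic carbon of the shared core and lies within the scatter.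

Compound 4 `COc1ccc(F)cc1CNCCCNc1ccnc2cc(-c3ccccc3)ccc12` differs from compound 2 in one place: phenyl in place of phenethyl on an aromatic carbon. The step from compound 1 to compound 2 bears on it directly, since it also replaces a group on the same aromatic carbon, and compound 3 carries a directly attached aryl group at that position with a value level with compound 2. Both point to no step beyond the scatter in this assay. Compound 4 is therefore expected to give 9.45, range 9.2 to 9.7, an expected step of a number 0.02 log units lower from compound 2 to compound 4 (within the scatter).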

Compound 4, acid dissociation constant: 9.47
The estimate for compound 4 lay 0.02 log units below the measured number; the measured number falls inside the stated range.
By their numbers in this assay, from the lowest: compounds 1, 2, 3 and 4 (each within the scatter of the next).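

In this assay, among the compounds shown here, phenyl in place of phenethyl on this aromatic carbon gives no change at the digits printed from compound 2 to compound 4 (within the scatter), the first step at this position that starts from phenethyl. Phenyl in place of 4-methoxyphenoxy gives a number 0.19 log units higher from compound 1 to compound 4 (within the scatter), so all three groups now compared at this carbon on one otherwise unchanged structure stay within the scatter of one another. No supporting measurement is available to explain this outcome.

Going by these compounds, whether a group carrying an amine or a carboxylic acid at this aromatic carbon would give a step beyond the scatter remains open. Also open, on these data alone, is whether the same holds when the rest of the structure differs from that shared by compounds 1, 2 and 4.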